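A few compounds are considered here, and "the series" means these few. Any claim that something is new, unique, unknown or untested is made for them only; others in the source may bear on it.

Compound 1, `O=C(Nc1ccccc1)Nc1cccc(CNc2nccnc2Cl)c1`: 19800 nM
Compound 2, `Cc1cccc(NC(=O)Nc2cccc(CNc3nccnc3Cl)c2)c1`: 9570 nM

Among the compounds with values here, in a functional assay on T-24 cells (Homo sapiens) for antiproliferative activity, read by MTT assay, with a stated time of 48 h (on this read-out lower numbers stand for stronger inhibition and higher numbers for weaker inhibition), compound 2 holds the lower of the two numbers; the only measured step is a 2.1-fold lower number from compound 1 to compound 2 (0.32 log units; beyond the scatter), a methyl in place of hydrogen on an aromatic carbon. Compound 3, `CCc1ccccc1NC(=O)Nc1cccc(CNc2nccnc2Cl)c1`, differs from compound 2 by 2-ethylphenyl in place of 3-methylphenyl on an amide-type nitrogen. Within the data shown here, no measured pair shows an ethyl group or this placement, so the single measured step gives only weak guidance, and a change of modest size, if any, is expected: a 1.3-fold higher number from compound 2 to compound 3 (0.10 log units; within the scatter). Compound 3 is therefore estimated at 12000 nM, within a range from 4000 nM to 36000 nM.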

Compound 3, half-maximal inhibitory concentration: 8720 nM
Compound 3: middle estimate off by 1.4-fold (0.14 log units), on the high side; the range from low to high includes it.
By their numbers in this assay, from the lowest: compounds 3 and 2 (each within the scatter of the next); then compound 1.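

In this assay, 2-ethylphenyl in place of 3-methylphenyl on the amide-type nitrogen leaves the number within the scatter (a 1.1-fold lower number from compound 2 to compound 3 (0.04 log units; within the scatter)), so this assay does not separate the two groups. The ethyl group gives a modest step (a 2.3-fold lower number from compound 1 to compound 3 (0.36 log units; beyond the scatter)), similar in size to the step seen with methyl (a 2.1-fold lower number from compound 1 to compound 2 (0.32 log units; beyond the scatter)). No measurement at hand gives a cause for these steps. On these data alone, it remains open how an amine, a carboxylic acid or a longer chain on this ring would compare, and how much the placement of the group matters apart from its size.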